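The compounds below may be only part of what the source reports. "The series", "measured", "known", "first", "only" and "open" are said of these compounds alone.

Compound 2 `COc1ccc([C@@H](CCCN(C)S(=O)(=O)c2cccs2)N2Cc3c(cccc3N3CCN(C4CC4)CC3)C2=O)cc1OC` carries a cyclopropyl on the ring amine nitrogen of the shared core. Going by the values given here, in a functional assay on RMS13 cells for antagonist activity at Urotensin-2 receptor (Homo sapiens), read by FLIPR and calcium flux, with a stated time of 1 h (on this read-out higher numbers stand for weaker inhibition and lower numbers for stronger inhibition), compound 2 gives 1200 nM, the higher of the two numbers measured so far and thus the weaker inhibitor of the pair. Compound 1 `COc1ccc([C@@H](CCCN(C)S(=O)(=O)c2cccs2)N2Cc3c(cccc3N3CCN(C4CCC4)CC3)C2=O)cc1OC`, which bears a cyclobutyl in that place, gives 510 nM, and the step of a 2.4-fold higher number from compound 1 to compound 2 (0.37 log units; beyond the scatter) shows that the smaller ring went with a higher number. Compound 3 `COc1ccc([C@@H](CCCN(C)S(=O)(=O)c2cccs2)N2Cc3c(cccc3N3CCN(C)CC3)C2=O)cc1OC` continues in the same direction: methyl in place of cyclopropyl on an amine nitrogen in a ring. Among the compounds with values here, only that single step bears on this change, so a further modest rise is expected, a 1.8-fold higher number from compound 2 to compound 3 (0.26 log units; within the scatter). Compound 3 is therefore estimated at 2200 nM, within 900 nM to 5500 nM.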

Compound 3, half-maximal inhibitory concentration: 340 nM
Estimate against measurement, compound 3: 6.5-fold (0.81 log units) above, and the stated range ends above it.
By their numbers in this assay, from the lowest: compounds 3 and 1 (each within the scatter of the next); then compound 2.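

Shrinking the group on the ring amine nitrogen does not keep raising the number: the step to methyl runs the opposite way, with a 3.5-fold lower number from compound 2 to compound 3 (0.55 log units; beyond the scatter). Compound 3 and compound 1 cannot be told apart, with a 1.5-fold lower number from compound 1 to compound 3 (0.18 log units; within the scatter), so in this assay methyl and cyclobutyl are equally tolerated here and only cyclopropyl stands out, with the higher number. No measurement shown here accounts for this reversal. Going by these compounds, it remains open whether an ethyl, an isopropyl or a plain hydrogen on this nitrogen would group with compound 3 and compound 1 or with compound 2.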